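Moving the Ring Nitrogen Back and Adding a Methoxy

The source may report more compounds than this note shows. Statements on the series, on what has been measured and on what is new or still open speak of the compounds shown alone.

Of the compounds shown here, three have been measured in an assay on isolated protein for inhibition of Rho-associated protein kinase 2 (Homo sapiens), read by radiometric assay and 33P incorporation, with a stated time of 40 min, in the presence of a further agent that is not named here; on this read-out lower numbers stand for stronger inhibition and higher numbers for weaker inhibition. Compound 1 `COc1cccc(CN2CCc3cc(-c4ccc5[nH]ncc5c4)ccc3C2=O)c1` gives 632 nM. Compound 2 `COc1cccc(Cn2cnc3sc(-c4ccncc4)cc3c2=O)c1`, which carries a pyridin-4-yl group on the shared core, gives 6 nM. Compound 3 `COc1cccc(Cn2cnc3sc(-c4cccnc4)cc3c2=O)c1`, with pyridin-3-yl in its place, gives 3480 nM, the highest number of the three and therefore the weakest inhibitor among them. Among the measured compounds shown here, the only single-change step measured so far, a 580-fold higher number from compound 2 to compound 3 (2.76 log units; beyond the scatter), shows how strongly the position of the ring nitrogen governs this read-out.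

Compound 4 `COc1cccc(Cn2cnc3sc(-c4ccnc(OC)c4)cc3c2=O)c1` has not been measured. It differs from compound 3 by 2-methoxypyridin-4-yl in place of pyridin-3-yl on an aromatic carbon. For the measured compounds named here, this returns the ring nitrogen to the position it occupies in compound 2, while the methoxy group is new; no measured pair shows what that group alone does. The step of a 580-fold higher number from compound 2 to compound 3 (2.76 log units; beyond the scatter) bears directly on the nitrogen position, and running it backwards suggests a large fall in the number. For compound 4 a value of 30 nM is therefore expected, most likely between 5 nM and 250 nM, because compound 2 gave 6 nM with the same nitrogen position. The expected step is a 120-fold lower number from compound 3 to compound 4 (2.06 log units; beyond the scatter), with the wide range reflecting the untested methoxy group.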

Compound 4, half-maximal inhibitory concentration: 6920 nM
The estimate for compound 4 lay 230-fold (2.36 log units) below the measured number, outside the stated range (above it).
By their numbers in this assay, from the lowest: compound 2; then compound 1; then compounds 3 and 4 (each within the scatter of the next).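

The methoxy group matters on its own: in this assay, adding it to the pyridin-4-yl ring gives a 1200-fold higher number from compound 2 to compound 4 (3.06 log units; beyond the scatter), so the ring nitrogen position of compound 2 does not by itself secure a low number. With that nitrogen position restored alongside the methoxy group, 2-methoxypyridin-4-yl brings no gain over pyridin-3-yl: the step is a 2.0-fold higher number from compound 3 to compound 4 (0.30 log units; within the scatter), and compound 3 and compound 4 cannot be told apart on this read-out. Nothing in the data at hand explains the loss.

On these data alone, what stays open is whether the loss belongs to methoxy in particular or would follow any group on that carbon of the pyridin-4-yl ring. A fluorine, a methyl or an amine there would show how much of the low number of compound 2 survives such an addition.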